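The source may hold more compounds than are shown below. What is called first, only, known or untested is meant among the compounds shown, and "the series" means these compounds.

Measured so far:
compound 1 `Cc1occc1-c1nnc2sc(-c3cc(O)nc(O)c3)nn12` — 6.25%
compound 2 `COc1ccc(Cl)c(-c2nnc3sc(Cc4c[nH]c5ccc(OC)cc45)nn23)c1` — 6.1%

In a functional assay on the whole organism (strain Wistar Albino) for inhibition, with Rattus norvegicus as the target, read by paw edema, with a stated time of 1 h, at a dose of 20 mg/kg (on this read-out higher numbers stand for more inhibition at the one dose given (going by the name of the read-out) and lower numbers for less inhibition), compound 1 gives 6.25% and compound 2 gives 6.1%. On the numbers shown compound 2 stands level with compound 1, the two values lying within the scatter of each other, so neither is set apart. For the measured compounds named here, no pair of measured compounds differs in one place, so no measured step is available as a guide.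

Compound 3 `COc1ccc2[nH]cc(Cc3nn4c(-c5ccoc5C)nnc4s3)c2c1` is not yet measured. It differs from compound 2 in one place: 2-methylfuran-3-yl in place of 2-chloro-5-methoxyphenyl on an aromatic carbon. The 2-methylfuran-3-yl group also appears in compound 1, whose reading in this assay is 6.25%; with both measured readings close together, the expectation is a step of no size beyond the scatter, in neither direction. Compound 3 is expected to give about 7%, in the range 0% to 18%. The estimated step of a number 0.9 percentage points higher from compound 2 to compound 3 (within the scatter) is thus expected to be none beyond the scatter.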

Compound 3, a percentage reported as inhibition, in the whole organism at one dose (the size of the read-out at that dose, not a potency): 16%
For compound 3 the middle estimate is 9 percentage points below the measured one, and the stated range covers the measured number.
By their numbers in this assay, from the lowest: compounds 2, 1 and 3 (each within the scatter of the next).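

In this assay, for the compounds shown here, 2-methylfuran-3-yl in place of 2-chloro-5-methoxyphenyl gives a number 9.9 percentage points higher from compound 2 to compound 3 (within the scatter), the only one-place step so far. On an aromatic carbon between two ring nitrogen atoms, a five-membered aromatic ring with 1 hetero atom therefore takes the place of a six-membered aromatic ring of carbon only, with no shift beyond the scatter in this read-out. No measurement shown bears on what lies behind this step.

From the compounds shown here alone, whether a group of another kind at this position, such as an amine or a carboxylic acid, would move the read-out beyond the scatter remains open. Also open, going by these compounds, is how the series behaves at other doses, as each reading comes from a single dose and time.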